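Swapping a Small Group on a Diaryl Urea

The source may hold more compounds than are shown below. What is called first, only, known or untested is meant among the compounds shown, and "the series" means these compounds.

Measured so far:
compound 1, `Cc1cc(C)nc(Sc2ccc(NC(=O)Nc3ccccc3)cc2)n1`, 22000 nM
compound 2, `Cc1cc(C)nc(Sc2ccc(NC(=O)Nc3ccc(OC(F)(F)F)cc3)cc2)n1`, 22800 nM

Both compounds share one core and differ only at one aromatic carbon. In a functional assay on CNE-2 cells (Homo sapiens) for cytotoxicity, read by MTT assay, with a stated time of 3 days (on this read-out higher numbers stand for weaker inhibition and lower numbers for stronger inhibition), compound 1 gives 22000 nM. In the same setting compound 2 gives 22800 nM. On these two numbers compound 2 holds the upper one, yet a 1.0-fold higher number from compound 1 to compound 2 (0.02 log units; within the scatter), so the two compounds cannot be told apart.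

Compound 3, `Cc1cc(C)nc(Sc2ccc(NC(=O)Nc3ccc(F)cc3)cc2)n1`, is not yet measured. It carries fluoro in place of trifluoromethoxy on an aromatic carbon. Among the measured compounds shown here, the only step that bears on this position is the earlier swap, from compound 1 to compound 2, which placed trifluoromethoxy where hydrogen had been; that step was a 1.0-fold higher number from compound 1 to compound 2 (0.02 log units; within the scatter). Nothing here suggests that a single fluorine at that same carbon would behave differently, so a change of a 1.0-fold lower number from compound 2 to compound 3 (0.02 log units; within the scatter) is expected, meaning no shift beyond the scatter. Compound 3 is therefore estimated at 22000 nM, in a range from 11000 nM to 45000 nM.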

Compound 3, half-maximal inhibitory concentration: 34100 nM
Compound 3: the middle estimate sits 1.6-fold (0.19 log units) below what was measured; the measured number falls inside the stated range.
By their numbers in this assay, from the lowest: compounds 1, 2 and 3 (each within the scatter of the next).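

With fluoro, this aromatic carbon has now carried three different substituents, and the comparison covers a much smaller group as well as a larger one. In this assay, replacing trifluoromethoxy with fluoro gives a 1.5-fold higher number from compound 2 to compound 3 (0.17 log units; within the scatter), while fluoro in place of hydrogen gives a 1.6-fold higher number from compound 1 to compound 3 (0.19 log units; within the scatter). Neither step separates the compounds, so hydrogen, a single fluorine and the five-heavy-atom trifluoromethoxy cannot be told apart at this position in this assay, and no measurement shown here offers an explanation for that.

From the compounds shown here alone, it remains open whether an amine, a carboxylic acid or a longer chain such as butoxy on this same carbon would produce a step beyond the scatter. The compounds shown also leave open how any of these groups would behave elsewhere on the same ring, or on other cell lines.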